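The source may report more compounds than this note shows. Statements on the series, on what has been measured and on what is new or still open speak of the compounds shown alone.

Working notes on a set of hydrazone amides built around a difluorophenyl-furan unit, tested in a functional assay on HL-60 cells (Homo sapiens) for inhibition, read by MTT assay, with a stated time of 48 h, tested at 10 uM; on this read-out lower numbers stand for less inhibition of growth and higher numbers for more inhibition of growth at the one concentration tested.

Compound 1 `O=C(N/N=C/c1ccc(-c2ccc(F)cc2F)o1)c1ccccc1O` and compound 2 `COc1ccccc1C(=O)N/N=C/c1ccc(-c2ccc(F)cc2F)o1` share one arrangement of the core; compound 3 `COc1ccccc1/C=N/NC(=O)c1ccc(-c2ccc(F)cc2F)o1` carries the same atoms joined differently, with the furan on the amide side and the substituted phenyl on the imine side, and the difference between the two cores is not broken down here. In this assay compound 1 gives -9.5%, compound 2 gives 7.77% and compound 3 gives 27.4%, so compound 3 stands highest of the three, beyond the scatter against both others.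

One single-point change is measured: hydrogen in place of methyl on an oxygen on an aromatic ring. The step of a number 17.3 percentage points lower from compound 2 to compound 1 (beyond the scatter).

Compound 4 `O=C(N/N=C/c1ccccc1O)c1ccc(-c2ccc(F)cc2F)o1` has not yet been measured in this assay. It is made from compound 3 by the same change, (hydrogen in place of methyl on an oxygen on an aromatic ring), the place being identical word for word, so it is the same change, now on the other core. Among the compounds with values here, because the only measured instance is a number 17.3 percentage points lower from compound 2 to compound 1 (beyond the scatter) and the two cores are not otherwise separated here, a step of about the same size and direction is expected from compound 3 to compound 4, namely a number 17.4 percentage points lower from compound 3 to compound 4 (beyond the scatter) as the estimate. Compound 4 is therefore estimated at 10% in this assay, with a likely range from -8% to 28%, the width reflecting that the step rests on a single pair.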

Compound 4, percent growth inhibition at one concentration: 43.1%
Compound 4: middle estimate off by 33.1 percentage points, on the low side; the measured number lies above the stated range.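

In this assay, the change from 2-methoxyphenyl to 2-hydroxyphenyl does not carry over from one core to the other, and its direction reverses: the same change on two cores in this assay, a number 17.3 percentage points lower (beyond the scatter) from compound 2 to compound 1 and a number 15.7 percentage points higher (beyond the scatter) from compound 3 to compound 4, 33 percentage points apart, beyond the scatter of two such steps

On the second core the measured step is a number 15.7 percentage points higher from compound 3 to compound 4 (beyond the scatter), so in this series a step measured on one core gives no reliable guide to the size or direction of the same change on the other. The result rests on a single pair for each core, so it shows that the outcome of this change differs between these two cores, but not which feature of the cores lies behind the difference, nor whether any other change would reverse in the same way.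

Going by these compounds, what an amine or an ethoxy group at this place would do on each core remains open, and with it whether the reversal belongs to the hydroxy group alone or extends to other replacements for methoxy. Also open, on these data alone, is whether the same reversal would appear across a range of concentrations, as the read-out in this assay gives growth inhibition at one concentration only.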